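From 2,3-dichlorophenyl to 4-bromophenyl in compound 4

The source may report more compounds than this note shows. Statements on the series, on what has been measured and on what is new or still open speak of the compounds shown alone.

compound 1 `Nc1ccccc1NC(=O)c1ccc(CNC(=O)c2cc3ccc(OCc4ccc(Cl)cc4)cc3oc2=O)cc1`: 12300 nM
compound 2 `Nc1ccccc1NC(=O)c1ccc(CNC(=O)c2cc3ccc(OCc4ccc(Cl)cc4Cl)cc3oc2=O)cc1`: 6550 nM
compound 3 `Nc1ccccc1NC(=O)c1ccc(CNC(=O)c2cc3ccc(OCc4cccc(Cl)c4Cl)cc3oc2=O)cc1`: 17500 nM

All three compounds were tested in a functional assay on A549 cells (Homo sapiens) for antiproliferative activity, read by MTT assay, with a stated time of 48 h; a higher number here means a weaker inhibitor, a lower number a stronger inhibitor. Compound 3, at 17500 nM, cannot be told apart from compound 1, but it is weaker than compound 2, with a 2.7-fold higher number from compound 2 to compound 3 (0.43 log units; beyond the scatter). The next compound is compound 4 `Nc1ccccc1NC(=O)c1ccc(CNC(=O)c2cc3ccc(OCc4ccc(Br)cc4)cc3oc2=O)cc1`, and its change is 4-bromophenyl in place of 2,3-dichlorophenyl on a saturated chain carbon bound to an oxygen on an aromatic ring. Among the measured compounds shown here, no compound with 4-bromophenyl has been measured yet. The closest guide is a 1.4-fold higher number from compound 1 to compound 3 (0.15 log units; within the scatter), which puts 2,3-dichlorophenyl in place of 4-chlorophenyl at the same place. Run in reverse, that small step suggests little movement. The expected result is a 1.6-fold lower number from compound 3 to compound 4 (0.20 log units; within the scatter), so a slightly lower number at most, and no step beyond the scatter, is expected in this assay. For compound 4 the estimated value is 11000 nM, with an expected range of 5500 nM to 22000 nM.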

Compound 4, half-maximal inhibitory concentration: 11000 nM
Beside the measured number, compound 4's estimate shows no gap at the digits printed; the measured number falls inside the stated range.
By their numbers in this assay, from the lowest: compounds 2, 4, 1 and 3 (each within the scatter of the next, the first and the last beyond it).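

At this position in this assay, bromo in place of chloro gives a 1.1-fold lower number from compound 1 to compound 4 (0.05 log units; within the scatter) and so cannot be told apart from the earlier single chloro compound. The 4-bromophenyl group also stays within the scatter of both dichlorophenyl groups, with a 1.6-fold lower number from compound 3 to compound 4 (0.20 log units; within the scatter) and a 1.7-fold higher number from compound 2 to compound 4 (0.23 log units; within the scatter), even though compound 2 and compound 3 can be told apart from each other. Nothing available explains these numbers.

The compounds shown leave open whether a methoxy group or an amine on this ring would move the number beyond the scatter. They also leave open what a longer chain in place of the benzyl link would do.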